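Benzyl in Place of Phenyl on a Shared Core

The source may hold more compounds than are shown below. What is called first, only, known or untested is meant among the compounds shown, and "the series" means these compounds.

Compound 3 `Cc1nc(Nc2ccccc2)c2cnn(-c3ccccc3)c2n1` carries a phenyl on a nitrogen on an aromatic ring. In a functional assay on G-361 cells (Homo sapiens) for cytotoxicity, read by sulforhodamine B assay (a lower number here means that less compound is tolerated, a higher number that more compound is tolerated), compound 3 gives only a limit, > 100000 nM. Compound 1 `CCCNc1nc(C)nc2c1cnn2-c1ccccc1`, with propyl in that place, also reaches only a limit in this assay, > 100000 nM. For compound 2 `Cc1nc(NC(C)C)c2cnn(-c3ccccc3)c2n1`, with isopropyl there, this assay likewise stops at a limit, > 100000 nM. All three values sit at the limit of > 100000 nM in this assay, at which 3 of the 3 values shown sit, so the steps a step that the two limits leave unreadable from compound 1 to compound 2, a step that the two limits leave unreadable from compound 1 to compound 3 and a step that the two limits leave unreadable from compound 2 to compound 3 cannot be read. Compound 4 `Cc1nc(NCc2ccccc2)c2cnn(-c3ccccc3)c2n1` differs from compound 3 by benzyl in place of phenyl on a nitrogen on an aromatic ring. The measured steps offer neither size nor direction. Compound 4 is therefore expected to remain at the limit, with a number no higher from compound 3 to compound 4 (the limit leaves the size open) meaning no readable change. The estimate for compound 4 is 100000 nM, between 30000 nM and 300000 nM.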

Compound 4, concentration lethal to 50% of the cells: > 100000 nM
Compound 4: no number, only a limit; the forecaster's own chance of this, stated with the estimate: 85%; the middle value lies on the limit itself.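

In this assay compound 4 reaches only a limit, > 100000 nM. Its steps from compound 1, compound 2 and compound 3 cannot be read. The compounds shown leave open whether the group on the nitrogen changes cytotoxicity at all.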